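A few compounds are considered here, and "the series" means these few. Any claim that something is new, unique, unknown or untested is made for them only; others in the source may bear on it.

Measured in a functional assay on L1210 cells (Mus musculus) for inhibition; a higher number here means a weaker inhibitor, a lower number a stronger inhibitor:
- compound 1 `Nc1nc(O)c2ncn(C/C=C\CO)c2n1`: 680000 nM
- compound 2 `Cc1cn(C/C=C\CCl)c(=O)[nH]c1=O`: 46000 nM

Of these two compounds, compound 2 has the lower number at 46000 nM, which makes it the stronger inhibitor in this assay. Compound 1, at 680000 nM, lies beyond the scatter on the weaker side. The next compound to be tested is compound 3 `Cc1cn(CC#CCO)c(=O)[nH]c1=O`. It keeps the core of compound 2 and carries 3-hydroxyprop-1-yn-1-yl in place of 3-chloroprop-1-en-1-yl on a saturated chain carbon bound to an aromatic nitrogen.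

Going by the values given here, no measured pair here differs in one place alone, so the expectation rests on thin evidence. Among the compounds with values here, the only compound with a chain ending in hydroxyl is compound 1 at 680000 nM, although its core differs as well. On that basis, a move toward weaker inhibition, beyond the scatter, is expected: the estimated change is a 5.4-fold higher number from compound 2 to compound 3 (0.74 log units; beyond the scatter). For compound 3 the estimated value is 250000 nM, with an expected range from 60000 nM to 1000000 nM.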

Compound 3, half-maximal inhibitory concentration: > 500000 nM
Compound 3 was reported as a limit; the forecaster's own chance of this, stated with the estimate: 35%; middle value at least 2.0-fold (0.30 log units) from the limit.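

Going by these compounds alone, at the place on a saturated chain carbon bound to an aromatic nitrogen, putting 3-hydroxyprop-1-yn-1-yl in place of 3-chloroprop-1-en-1-yl gives an at least 10-fold higher number from compound 2 to compound 3 (1.03 log units; beyond the scatter) in this assay, and this is the first change in one place alone that can be read. The two groups count the same 4 heavy atoms, so this large weakening comes without a change in that count, while chlorine gives way to oxygen, a double bond gives way to a triple bond, and a hydrogen-bond donor and a hydrogen-bond acceptor enter. Compound 3 stands as a limit and not as a measured number, so the true size of the step stays unknown: the limit of > 500000 nM in this assay, at which 1 of the 3 values shown sits.

Going by these compounds, the step changes the end atom of the chain and its unsaturated bond at once, so it remains open which of the two carries the weakening, a question that 3-chloroprop-1-yn-1-yl or 3-hydroxyprop-1-en-1-yl at this place would separate. On these data alone, how a chain ending in an amine, or a longer chain, would fare at this place also remains open.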